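Swapping a Hydroxy Amide for an Acetylphenyl Amide

A few compounds are considered here, and "the series" means these few. Any claim that something is new, unique, unknown or untested is made for them only; others in the source may bear on it.

Of the compounds shown here, three sharing one core have been tested in a functional assay on CLL cells (Homo sapiens) for cytotoxicity, read by MTT assay, with a stated time of 48 h; on this read-out lower numbers stand for an effect already at smaller amounts and higher numbers for an effect only at larger amounts of compound. Compound 1 `C=C(CC)C(=O)c1ccc(OCC(=O)NCCO)c(Cl)c1Cl` gives only a limit rather than a number in this assay, namely > 25000 nM. Compound 2 `C=C(CC)C(=O)c1ccc(OCC(=O)Nc2ccc(S(=O)(=O)O)cc2)c(Cl)c1Cl` likewise reaches only a limit in this assay, > 25000 nM. Among the compounds with values here, compound 3 `C=C(CC)C(=O)c1ccc(OCC(=O)NO)c(Cl)c1Cl` gives 4500 nM in this assay, the only proper number among the three. Within the data shown here, the single measured step, an at least 5.5-fold lower number from compound 1 to compound 3 (0.74 log units; beyond the scatter), shows that putting the hydroxy onto the amide-type nitrogen brings an effect at smaller amounts, though its exact size stays open because of the limit of > 25000 nM in this assay, at which 2 of the 3 values shown sit.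

Compound 4 `C=C(CC)C(=O)c1ccc(OCC(=O)Nc2ccc(C(C)=O)cc2)c(Cl)c1Cl` differs from compound 3 in one place: 4-acetylphenyl in place of hydroxy on an amide-type nitrogen. This change removes the hydroxy on the amide-type nitrogen, the very group whose arrival gave the only clear gain, while compound 1 and compound 2, which also lack it, sit at the limit. The step is therefore expected to run upward, a 6.7-fold higher number from compound 3 to compound 4 (0.82 log units; beyond the scatter), most likely back to the limit. Compound 4 is expected to give about 30000 nM in this assay, within 8000 nM to 100000 nM.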

Compound 4, half-maximal effective concentration: 3900 nM
Beside the measured number, compound 4's estimate is 7.7-fold (0.89 log units) above it; measured number below the stated range.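

In this assay, the step shows a 1.2-fold lower number from compound 3 to compound 4 (0.06 log units; within the scatter), so the hydroxy on the amide-type nitrogen is not required: a 4-acetylphenyl group in that place gives a value that cannot be told apart from that of the hydroxy compound. The aromatic ring alone does not decide the outcome, since acetyl in place of sulfo on that ring gives an at least 6.4-fold lower number from compound 2 to compound 4 (0.80 log units; beyond the scatter), while 4-acetylphenyl in place of 2-hydroxyethyl gives an at least 6.4-fold lower number from compound 1 to compound 4 (0.80 log units; beyond the scatter). The exact size of these two steps stays open because both start from a limit: the limit of > 25000 nM in this assay, at which 2 of the 4 values shown sit.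

Still open, on these data alone, is whether the acetyl matters at all, which a bare phenyl, or an amine or a carboxylic acid in its place on the ring, could show. Also open, as far as these compounds go, is how a longer chain between the amide-type nitrogen and the ring would compare.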